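A second methoxy on compound 2

This account rests on a few compounds, and the source may have more. Where it says the series, first, only, none or still open, it means among the compounds named here.

Measured so far:
- Compound 1 `Oc1ccc(CNc2ncnc3c2ncn3C2CCCCO2)cc1`: > 100000 nM in an ADME assay on MCF7 cells (Homo sapiens) for cytotoxicity, with a stated time of 72 h (a higher number here means a weaker inhibitor, a lower number a stronger inhibitor), a limit
- Compound 2 `COc1cccc(CNc2ncnc3c2ncn3C2CCCCO2)c1`: 97000 nM in this assay
- Compound 3 `COc1cc(CNc2ncnc3c2ncn3C2CCCCO2)ccc1O`: > 100000 nM in this assay, a limit

Among the compounds with values here, compound 2, at 97000 nM, is the only compound with an actual number. The values of compound 1 and compound 3 are limits. Compound 4 `COc1cc(CNc2ncnc3c2ncn3C2CCCCO2)cc(OC)c1` differs from compound 2 by methoxy in place of hydrogen on an aromatic carbon, meta to a methoxy group. The same kind of change appears in a step that the two limits leave unreadable from compound 1 to compound 3. Two further steps bear on it: an at least 1.0-fold lower number from compound 1 to compound 2 (0.01 log units; that floor lies within the scatter) and an at least 1.0-fold higher number from compound 2 to compound 3 (0.01 log units; that floor lies within the scatter). Neither shows a step beyond the scatter. The step expected in this assay is therefore a 1.1-fold lower number from compound 2 to compound 4 (0.03 log units; within the scatter), with no clear direction. For compound 4 the estimated value is 90000 nM, with an expected range of 45000 nM to 150000 nM.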

Compound 4, half-maximal inhibitory concentration: > 100000 nM
Compound 4: a limit, no number (the forecaster's own chance of this, stated with the estimate: 45%); middle value at least 1.1-fold (0.04 log units) from the limit.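

In this assay, the methoxy placed meta to a methoxy group gives an at least 1.0-fold higher number from compound 2 to compound 4 (0.01 log units; that floor lies within the scatter), so unlike the unreadable step from compound 1 to compound 3, this methoxy change has a readable floor. The value of compound 4 is a limit, not a number. This addition therefore produces no measured number lower than that of compound 2, and the compounds mostly collect at one value: the limit of > 100000 nM in this assay, at which 3 of the 4 values shown sit.

On these data alone, the true size of this step stays open. As far as these compounds go, it also remains open whether an amine or a carboxylic acid at this place would give a number clearly lower than that of compound 2.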